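Cyclohexyl in place of pyridin-3-yl at the chain end

The source may report more compounds than this note shows. Statements on the series, on what has been measured and on what is new or still open speak of the compounds shown alone.

Measured so far, in an assay on HEK293 cells for inhibition of N-acylethanolamine-hydrolyzing acid amidase (Rattus norvegicus), read by LC-MS, with a stated time of 30 min; a lower number here means a stronger inhibitor, a higher number a weaker inhibitor:
compound 1 `O=C(CCCCCCc1cccc(Cl)c1)N1CCCC1` gives 3700 nM;
compound 2 `O=C(CCCCCCc1ccccn1)N1CCCC1` gives > 100000 nM, which is a limit of the assay;
compound 3 `O=C(CCCCCCc1cccnc1)N1CCCC1` gives > 100000 nM, also a limit of the assay.

Compound 3 thus stands only at a limit, not at a number. Among the compounds with values here, the one step among the measured compounds, a step that the two limits leave unreadable from compound 2 to compound 3, cannot be sized, since the limit of > 100000 nM in this assay, at which 2 of the 3 values shown sit, hides both ends. Compound 4 `O=C(CCCCCCC1CCCCC1)N1CCCC1` differs from compound 3 by cyclohexyl in place of pyridin-3-yl on a saturated chain carbon, six bonds along the chain from a carbonyl carbon.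

Within the data shown here, no measured step matches this change. What the numbers show is that compound 1, whose ring holds no nitrogen, gives a readable value, whereas compound 2 and compound 3, each with a nitrogen in the ring, sit at the limit. Compound 4, with a ring of carbon only, is therefore expected to land nearer to compound 1 than to the limit, with a step of an at least 16-fold lower number from compound 3 to compound 4 (1.22 log units; beyond the scatter) estimated toward stronger inhibition. The estimate for compound 4 is 6000 nM, within 1200 nM to 60000 nM.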

Compound 4, half-maximal inhibitory concentration: 5700 nM
Compound 4: middle estimate off by 1.1-fold (0.02 log units), on the high side; measured number inside the range.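

In this assay, cyclohexyl in place of pyridin-3-yl gives an at least 17-fold lower number from compound 3 to compound 4 (1.24 log units; beyond the scatter), and cyclohexyl in place of pyridin-2-yl gives an at least 17-fold lower number from compound 2 to compound 4 (1.24 log units; beyond the scatter). So a readable value at this place, on a saturated chain carbon, six bonds along the chain from a carbonyl carbon, does not need an aromatic ring, since compound 4 carries a non-aromatic ring of carbon only. Both steps are minimum sizes, because each starts from a limit rather than a number: the limit of > 100000 nM in this assay, at which 2 of the 4 values shown sit.

From the compounds shown here alone, the order of pyridin-2-yl and pyridin-3-yl remains unknown, as the step between them cannot be read. Also open, going by these compounds, is what an unsubstituted phenyl ring, a smaller cyclopentyl ring or an amine on the cyclohexyl ring would give at the chain end.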